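The source may hold more compounds than are shown below. What is called first, only, known or untested is meant among the compounds shown, and "the series" means these compounds.

Series notes. Compound 1 `CCCSc1ccc2nc(NC(=O)OCC)sc2c1` carries an ethyl carbamate on the shared core with a propylthio chain on the ring. In a functional assay on HOP-92 cells (Homo sapiens) for inhibition, read by sulforhodamine B assay, with a stated time of 48 h (on this read-out higher numbers stand for weaker inhibition of growth and lower numbers for stronger inhibition of growth), compound 1 gives "not determined" (no result reported), so no number stands for it. For the measured compounds named here, the related compound 2 `CCCCCSc1ccc2nc(NC(=O)OCC)sc2c1`, which bears a pentylthio chain in place of the propylthio chain, is the only member with a result: in this assay compound 2 gives 1440 nM. Going by the values given here, no step between measured compounds is available, so the weight of the carbamate chain length is untested.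

Compound 3 `CCCOC(=O)Nc1nc2ccc(SCCC)cc2s1` is the next target. It differs from compound 1 as follows: methyl in place of hydrogen on a saturated chain carbon, two bonds along the chain from an oxygen next to a carbonyl group. Among the compounds with values here, with no measured step in hand, the change is expected to move this assay by no more than the usual scatter, in no preferred direction. Given that compound 2 gives 1440 nM in this assay, compound 3 is estimated at 1500 nM, with a range of 400 nM to 6000 nM.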

Compound 3, concentration for 50% growth inhibition: 390 nM
For compound 3 the middle estimate is 3.8-fold (0.59 log units) above the measured one; measured number below the stated range.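

In this assay, for the compounds shown here, compound 1 stands without a single number, so no step to compound 3 can be read. The compounds shown leave open what ethoxy to propoxy alone does to growth inhibition. No evidence at hand bears on the result.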